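Amino ester variation on a shared oxalanilide core

A few compounds are considered here, and "the series" means these few. Any claim that something is new, unique, unknown or untested is made for them only; others in the source may bear on it.

Measured compounds in an assay on mitochondria from liver for inhibition of Amine oxidase [flavin-containing] A (Rattus norvegicus), with a stated time of 60 min; a higher number here means a weaker inhibitor, a lower number a stronger inhibitor:
- compound 1, `CCOC(=O)c1ccc(NC(=O)C(=O)c2ccccc2NC(C)=O)cc1`, gives 83 nM
- compound 2, `COC(=O)[C@H](C)NC(=O)c1ccc(NC(=O)C(=O)c2ccccc2NC(C)=O)cc1`, gives 36 nM
- compound 3, `COC(=O)[C@@H](NC(=O)c1ccc(NC(=O)C(=O)c2ccccc2NC(C)=O)cc1)C(C)C`, gives 2.8 nM

Compound 3 stands at the lowest number of the three. The step of a 13-fold lower number from compound 2 to compound 3 (1.11 log units; beyond the scatter) and the step of a 30-fold lower number from compound 1 to compound 3 (1.47 log units; beyond the scatter) both lie beyond the scatter, so compound 3 is the strongest inhibitor among the measured compounds. The smaller step of a 2.3-fold lower number from compound 1 to compound 2 (0.36 log units; beyond the scatter) shows that the amino ester alone adds something, but most of the gain comes with the isopropyl on the saturated chain carbon bound to an amide-type nitrogen and a carbonyl carbon.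

The next compound is compound 4, `COC(=O)C[C@H](NC(=O)c1ccc(NC(=O)C(=O)c2ccccc2NC(C)=O)cc1)C(=O)OC`. The change from compound 3 is (methoxycarbonyl)methyl in place of isopropyl on a saturated chain carbon bound to an amide-type nitrogen and a carbonyl carbon. Among the compounds with values here, only one measured step touches this carbon, namely a 13-fold lower number from compound 2 to compound 3 (1.11 log units; beyond the scatter), where methyl gave way to isopropyl. Within the data shown here, no measured step replaces isopropyl with a (methoxycarbonyl)methyl group, so the direction is uncertain. The step from methyl to isopropyl was large, and the new group is neither; a number between those of compound 2 and compound 3 seems the most defensible expectation, that is a step of a 4.3-fold higher number from compound 3 to compound 4 (0.63 log units; beyond the scatter) in this assay. Compound 4 is therefore estimated at 12 nM, within 3 nM to 50 nM.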

Compound 4, half-maximal inhibitory concentration: 60 nM
Beside the measured number, compound 4's estimate is 5.0-fold (0.70 log units) below it, and the stated range ends below it.
By their numbers in this assay, from the lowest: compound 3; then compounds 2, 4 and 1 (each within the scatter of the next, the first and the last beyond it).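

In this assay, a 21-fold higher number from compound 3 to compound 4 (1.33 log units; beyond the scatter) shows that the gain seen with isopropyl on this saturated chain carbon does not carry over to (methoxycarbonyl)methyl, even though the entering group has 5 heavy atoms against 3 and 2 hydrogen-bond acceptors against 0. Since a 1.7-fold higher number from compound 2 to compound 4 (0.22 log units; within the scatter) and a 1.4-fold lower number from compound 1 to compound 4 (0.14 log units; within the scatter) both lie within the scatter, no difference can be read among these three compounds, and among the side groups shown only the isopropyl of compound 3 gives a number clearly apart from the rest. No supporting data on these compounds bear on this result.

Going by these compounds, it remains open whether the low number of compound 3 at 2.8 nM depends on isopropyl itself or would also be reached with an isobutyl, tert-butyl or benzyl group on this carbon. On these data alone, it is equally open whether a free carboxylic acid in place of the methyl ester within (methoxycarbonyl)methyl, or a longer chain carrying that ester, would change the number in this assay at all.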